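From Fluoro to Bromo in a Small Halogen Series

The source may hold more compounds than are shown below. What is called first, only, known or untested is meant among the compounds shown, and "the series" means these compounds.

Among the measured compounds shown here, in a functional assay on L1210 cells (Mus musculus) for inhibition (on this read-out higher numbers stand for weaker inhibition and lower numbers for stronger inhibition), compound 1 `O=C1/C(=C/c2ccc(F)cc2)Cc2ccccc21` gives 89000 nM, the highest of the three numbers measured so far, which makes it the weakest inhibitor of the three. Compound 2 `O=C1/C(=C/c2cccc(Cl)c2)Cc2ccccc21` gives 41200 nM, and compound 3 `O=C1/C(=C/c2cccc(Br)c2)Cc2ccccc21` gives 43300 nM. Compound 4 `O=C1/C(=C/c2ccc(Br)cc2)Cc2ccccc21` has not yet been measured. It differs from compound 1 by bromo in place of fluoro on an aromatic carbon. For the measured compounds named here, no measured step makes this exact swap. The closest is a 1.1-fold higher number from compound 2 to compound 3 (0.02 log units; within the scatter), where bromo replaces chloro, and that step stays within the scatter. It shows that one such exchange left the number unmoved, but it says nothing direct about removing fluoro. Compound 3, which also carries bromo, gives 43300 nM, a hint that the new compound may land below compound 1. In this assay, a modest move to a lower number is therefore expected, a 1.6-fold lower number from compound 1 to compound 4 (0.21 log units; within the scatter). For compound 4 the estimated value is 55000 nM, with an expected range from 22000 nM to 110000 nM.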

Compound 4, half-maximal inhibitory concentration: 64800 nM
Compound 4: the middle estimate sits 1.2-fold (0.07 log units) below what was measured, within the range that was stated.
By their numbers in this assay, from the lowest: compounds 2, 3, 4 and 1 (each within the scatter of the next, the first and the last beyond it).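

In this assay the exchange of fluoro for bromo, on an aromatic carbon para to a large group, gives a 1.4-fold lower number from compound 1 to compound 4 (0.14 log units; within the scatter) and so stays within the scatter: at this position, the two halogens cannot be told apart. Among the compounds shown here, this is the first direct reading of a step in which fluoro leaves, and it joins a 1.1-fold higher number from compound 2 to compound 3 (0.02 log units; within the scatter) as a second halogen exchange that stays within the scatter, although that earlier step involved chloro and bromo. No measurement here explains why the number stays within the scatter.

The compounds shown leave open whether a group other than a halogen at this position, such as an amine, a carboxylic acid or a longer chain, would move the number beyond the scatter. They also leave open how chloro would read at this same position.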